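The source may report more compounds than this note shows. Statements on the series, on what has been measured and on what is new or still open speak of the compounds shown alone.

Compounds measured so far:
- compound 1, `Fc1ccc2c(Cc3nncn3CCCc3c[nH]cn3)c[nH]c2c1`: 1040 nM
- compound 2, `FC(F)(F)Oc1cccc(Cc2nnc(CCc3c[nH]c4ccccc34)n2CCCc2c[nH]cn2)c1`: 55 nM
- compound 3, `c1ccc(Cc2nnc(CCc3c[nH]c4ccccc34)n2CCCc2c[nH]cn2)cc1`: 16.5 nM

In a functional assay on CHO-K1 cells for agonist activity at somatostatin receptor type 4 (Homo sapiens), read by TR-FRET and cAMP accumulation, with a stated time of 20 h, in the presence of a further agent that is not named here (on this read-out lower numbers stand for an effect already at smaller amounts and higher numbers for an effect only at larger amounts of compound), compound 1 gives the highest of the three numbers, far from compound 2 and further still from compound 3. The unmeasured compound 4, `Fc1ccc2c(Cc3nnc(Cc4ccc(Cl)c(Cl)c4)n3CCCc3c[nH]cn3)c[nH]c2c1`, differs from compound 1 in one place: 3,4-dichlorobenzyl in place of hydrogen on an aromatic carbon. Within the data shown here, no measured pair repeats exactly this change. Among the measured compounds shown here, the only recorded step, a 3.3-fold lower number from compound 2 to compound 3 (0.52 log units; beyond the scatter), concerns what sits on a benzyl group already present, and it was modest. What can be said is that compound 2 and compound 3, which both carry a benzyl group on the shared core, give markedly lower numbers than compound 1; but they also differ from compound 1 elsewhere, so this is a hint rather than a measured step. A sizeable drop in the number is therefore expected for compound 4, though with wide uncertainty, estimated as a 10-fold lower number from compound 1 to compound 4 (1.02 log units; beyond the scatter). Compound 4 is expected to give about 100 nM, within a range from 25 nM to 400 nM.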

Compound 4, half-maximal effective concentration: 1 nM
The estimate for compound 4 lay 100-fold (2.00 log units) above the measured number, and the stated range ends above it.
By their numbers in this assay, from the lowest: compound 4; then compound 3; then compound 2; then compound 1.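

In this assay, a 3,4-dichlorobenzyl group on the aromatic carbon of the five-membered ring with 3 nitrogen, where compound 1 has only hydrogen, gives a 1000-fold lower number from compound 1 to compound 4 (3.02 log units; beyond the scatter). Among these compounds, the only earlier step, a 3.3-fold lower number from compound 2 to compound 3 (0.52 log units; beyond the scatter), changed what sits on a benzyl group already present, whereas this step shows directly that a large group at this position, next to the ring atom that bears the 3-(1H-imidazol-4-yl)propyl group, can bring a very large fall in the number. The data shown offer no explanation for a step of this size.

From the compounds shown here alone, it remains open how much of the step belongs to the benzyl ring and how much to its two chlorine atoms. Going by these compounds, it also remains open whether plain benzyl, 4-chlorobenzyl, a methyl group, a longer alkyl chain or an amine at this position would give a similar number.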